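A few compounds are considered here, and "the series" means these few. Any claim that something is new, unique, unknown or untested is made for them only; others in the source may bear on it.

Three compounds of one shared core have numbers in a functional assay on MCF7 cells (Homo sapiens) for inhibition, read by MTT assay, with a stated time of 72 h; a higher number here means a weaker inhibitor of growth, a lower number a stronger inhibitor of growth. Compound 1 `N#C/C(=C\c1ccc[nH]1)C(=O)NCc1ccc(Cl)c(Cl)c1` gives 6000 nM, compound 2 `COc1ccc(CNC(=O)/C(C#N)=C/c2ccc(C)o2)cc1` gives 21000 nM, and compound 3 `COc1ccc(CNC(=O)/C(C#N)=C/c2ccc(-c3ccccc3)o2)cc1` gives 3000 nM; compound 2 thus stands highest of the three, that is, it is the weakest. Going by the values given here, the only measured step that changes the same ring, a 7.0-fold lower number from compound 2 to compound 3 (0.85 log units; beyond the scatter), is modest. Compound 4 `COc1ccc(CNC(=O)/C(C#N)=C/c2cc(Br)co2)cc1` differs from compound 2 by 4-bromofuran-2-yl in place of 5-methylfuran-2-yl on a double-bonded chain carbon bound to a double-bonded chain carbon. Among the compounds with values here, no measured step exchanges the methyl for a bromine or moves a group on that ring, so the direction rests on that single step alone. For compound 4 a small drop in number is expected, a 1.8-fold lower number from compound 2 to compound 4 (0.24 log units; within the scatter), giving an estimated 12000 nM with a likely range from 5000 nM to 30000 nM.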

Compound 4, concentration for 50% growth inhibition: 20000 nM
Compound 4: the middle estimate sits 1.7-fold (0.22 log units) below what was measured; the measured number falls inside the stated range.
By their numbers in this assay, from the lowest: compounds 3 and 1 (each within the scatter of the next); then compounds 4 and 2 (each within the scatter of the next).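

In this assay, a 1.1-fold lower number from compound 2 to compound 4 (0.02 log units; within the scatter) lies within the scatter, so at this place, on a double-bonded chain carbon bound to a double-bonded chain carbon, 4-bromofuran-2-yl and 5-methylfuran-2-yl cannot be told apart. The earlier step, a 7.0-fold lower number from compound 2 to compound 3 (0.85 log units; beyond the scatter), lies beyond the scatter, so this new result shows that not every change to the furan ring of compound 2 moves the number. No evidence is available that bears on this result.

From the compounds shown here alone, whether an amine or a carboxylic acid in place of the methyl of compound 2 would shift the number remains open.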